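Trifluoromethoxy to methoxy on compound 1

The source may hold more compounds than are shown below. What is called first, only, known or untested is meant among the compounds shown, and "the series" means these compounds.

In an ADME assay on Raji cells (Homo sapiens) for cytotoxicity, with a stated time of 72 h (a higher number here means that more compound is needed for the effect, a lower number that less compound is needed), compound 1 (`Cc1cc(NC(=O)Nc2ccccc2OC(F)(F)F)c2ccccc2n1`) reaches only a limit, > 25000 nM. Compound 2 (`Cc1cc(NC(=O)Nc2ccc(C(F)(F)F)cc2)c2ccccc2n1`) gives a measured 23000 nM. Compound 3 (`Cc1cc(NC(=O)Nc2ccc(C(N)=O)cc2)c2ccccc2n1`) also gives only a limit, > 25000 nM. The picture so far is the limit of > 25000 nM in this assay, at which 2 of the 3 values shown sit. Compound 4 (`COc1ccccc1NC(=O)Nc1cc(C)nc2ccccc12`) differs from compound 1 by methyl in place of trifluoromethyl on an oxygen on an aromatic ring, which is methyl in place of trifluoromethyl on an oxygen on an aromatic ring. Within the data shown here, the one measured step, an at least 1.0-fold higher number from compound 2 to compound 3 (0.03 log units; that floor lies within the scatter), has carbamoyl in place of trifluoromethyl on an aromatic carbon, so it bears only loosely on this change. No step beyond the scatter is therefore expected, and the estimated step is a number no higher from compound 1 to compound 4 (the limit leaves the size open). For compound 4 the expected value is 25000 nM, with an estimated range of 12000 nM to 50000 nM.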

Compound 4, half-maximal effective concentration: > 25000 nM
Compound 4: no number, only a limit (the forecaster's own chance of this, stated with the estimate: 65%); the middle value lies on the limit itself.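

Compound 1 and compound 4 both stand only at a limit, so the step between them cannot be read. The compounds shown leave open whether trifluoromethoxy and methoxy differ at all in this assay, where most values sit at one point: the limit of > 25000 nM in this assay, at which 3 of the 4 values shown sit.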